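Swapping a fluorophenyl for a cyclopropyl and watching stability

A few compounds are considered here, and "the series" means these few. Any claim that something is new, unique, unknown or untested is made for them only; others in the source may bear on it.

Compound 1 `CCCCc1nc(=O)c(S(=O)(=O)c2ccc(-c3ccc(F)cc3)cc2)c(O)n1-c1c(OC)cccc1OC` is the reference point here. In an ADME assay on microsomes from liver (Rattus norvegicus) for metabolic stability, using NADPH, with a stated time of 10 min (a higher number here means that more of the compound is left, a lower number that less of the compound is left), compound 1 gives 5%, which on its own number sits very low: almost all of the compound is gone within the stated time. Within the data shown here, it is the only compound with a measured value. Compound 2 `CCCCc1[nH]c(=O)c(S(=O)(=O)c2ccc(-c3ccc(F)nc3)cc2)c(O)c1-c1c(OC)cccc1OC`, a relative with a different core, carries the entry "not determined" (no result reported) in this assay, so no number is known for it and it offers no guidance.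

Compound 3 `CCCCc1nc(=O)c(S(=O)(=O)c2ccc(C3CC3)cc2)c(O)n1-c1c(OC)cccc1OC` shares the core of compound 1 and differs in one place only. The change is cyclopropyl in place of 4-fluorophenyl on an aromatic carbon. Among the measured compounds shown here, no measured pair shows what such a swap does to the fraction remaining, so nothing about its direction can be read from the data. The starting value of compound 1 is already near the bottom of the scale, which leaves little room downward and more room upward.

The step from compound 1 to compound 3 is expected to be small, at a number 5 percentage points higher from compound 1 to compound 3 (within the scatter), within the usual scatter. Compound 3 is therefore estimated at 10%, with a likely range from 2% to 30%.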

Compound 3, percent of the compound remaining: 59%
Beside the measured number, compound 3's estimate is 49 percentage points below it; measured number above the stated range.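

In this assay, the group at this position, on an aromatic carbon para to a large group, turns out to have a strong bearing on how much compound is left: cyclopropyl in place of 4-fluorophenyl comes with a number 54 percentage points higher from compound 1 to compound 3 (beyond the scatter) and moves the series away from the bottom of the scale. The group that leaves is a six-membered aromatic ring of carbon only, carrying fluorine, and the group that enters is a three-membered non-aromatic ring of carbon only, while neither has hydrogen-bond donors, hydrogen-bond acceptors or a net charge, so the large step comes with no difference in those counts. Nothing measured here tells why the fraction remaining differs so much between these two groups.

A single pair cannot separate the loss of the fluorine from the loss of the aromatic ring or from the drop in size, and a plain phenyl, an isopropyl or a piperidine at the same place could begin to do so. As far as these compounds go, whether the same swap would act alike on another core also stays open.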